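Ester series: replacing the aroyl ring, lipophilicity notes

A few compounds are considered here, and "the series" means these few. Any claim that something is new, unique, unknown or untested is made for them only; others in the source may bear on it.

Measured so far:
compound 1 `C=CCc1ccc(OC(=O)c2ccc(Cl)cc2)c(OC)c1` in a physicochemical assay for lipophilicity; on this read-out higher numbers stand for higher lipophilicity and lower numbers for lower lipophilicity: compound 1 gives 2.79
compound 2 `C=CCc1ccc(OC(=O)c2ccccn2)c(OC)c1` in this assay: compound 2 gives 0.86
compound 3 `C=CCc1ccc(OC(=O)c2ccccc2F)c(OC)c1` in this assay: compound 3 gives 2.7

On these numbers compound 1 stands highest of the three; compound 3 sits nearest, its step of a number 0.09 log units lower from compound 1 to compound 3 (within the scatter) lying within the scatter, while compound 2 sits furthest, the step of a number 1.93 log units lower from compound 1 to compound 2 (beyond the scatter) being large and beyond the scatter.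

The next compound to be measured is compound 4 `C=CCc1ccc(OC(=O)c2cccnc2)c(OC)c1`. Compared with compound 1 the change is pyridin-3-yl in place of 4-chlorophenyl on a carbonyl carbon.

Among the measured compounds shown here, the step that bears on this is the one to compound 2, where a pyridin-2-yl took the place of the same 4-chlorophenyl: a number 1.93 log units lower from compound 1 to compound 2 (beyond the scatter). The reverse comparison a number 1.84 log units higher from compound 2 to compound 3 (beyond the scatter) shows the same gap from the other side. For the measured compounds named here, compound 4 carries a pyridin-3-yl rather than a pyridin-2-yl, for which no measured pair exists, so the size is taken from the pyridin-2-yl case and given a wider range. A large downward step is therefore expected, a number 1.79 log units lower from compound 1 to compound 4 (beyond the scatter).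

Compound 4 is estimated at 1 in this assay, within a range of 0.5 to 1.6.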

Compound 4, partition coefficient: 0.86
The estimate for compound 4 lay 0.14 log units above the measured number; the range from low to high includes it.
By their numbers in this assay, from the lowest: compounds 2 and 4 (each within the scatter of the next); then compounds 3 and 1 (each within the scatter of the next).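

In this assay, among the compounds shown here, exchanging one pyridine for the other on the carbonyl carbon gives no change at the digits printed from compound 2 to compound 4 (within the scatter) and so, for these two compounds, the ring attachment of the pyridine leaves no readable mark on the number, whereas the earlier compounds offered only a single pyridine. The large fall is therefore not peculiar to pyridin-2-yl: pyridin-3-yl in place of 4-chlorophenyl gives a number 1.93 log units lower from compound 1 to compound 4 (beyond the scatter) and pyridin-3-yl in place of 2-fluorophenyl gives a number 1.84 log units lower from compound 3 to compound 4 (beyond the scatter) so that, among the four compounds, the two pyridines stand together and well apart from the two halogen-bearing phenyl compounds. Nothing in the data shown accounts for this separation.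

As far as these compounds go, whether a pyridin-4-yl or an unsubstituted phenyl on the same carbonyl carbon would fall with the pyridine pair, with the halogen-bearing pair or somewhere in the wide gap between them remains open. Also open, from the compounds shown here alone, is whether a pyrimidine ring, an aminophenyl or a benzoic acid at this place would extend the same picture, and whether the pyridine steps carry over when the allyl chain of the shared core is replaced by a longer chain.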